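Swapping a Dimethylphenyl for a Tert-Butylphenyl Isomer

The source may hold more compounds than are shown below. What is called first, only, known or untested is meant among the compounds shown, and "the series" means these compounds.

Compound 2 `COc1cc(NC(=O)Nc2cc(Nc3ccc(C)c(C)c3)ncn2)cc(OC)c1` stands highest of the two numbers in a functional assay on NCI-H520 cells (Homo sapiens) for inhibition, read by MTT assay, with a stated time of 48 h, tested at 10 uM (a lower number here means less inhibition, a higher number more inhibition at the concentration tested (going by the name of the read-out)), where compound 2 gives 29.5%. Compound 1 `COc1cc(NC(=O)Nc2cc(Nc3ccc(C(C)(C)C)cc3)ncn2)cc(OC)c1` gives 17.5%, and the step of a number 12 percentage points higher from compound 1 to compound 2 (beyond the scatter) lies beyond the scatter. Compound 3 `COc1cc(NC(=O)Nc2cc(Nc3cccc(C(C)(C)C)c3)ncn2)cc(OC)c1` differs from compound 2 in one place: 3-(tert-butyl)phenyl in place of 3,4-dimethylphenyl on a nitrogen on an aromatic ring. Within the data shown here, only that single measured step bears on this change, and it showed 3,4-dimethylphenyl in place of 4-(tert-butyl)phenyl raising the number modestly. Bringing back a tert-butyl group, now as 3-(tert-butyl)phenyl, is therefore expected to lower the number modestly, by a number 7.5 percentage points lower from compound 2 to compound 3 (within the scatter). Compound 3 is estimated at 22%, within 10% to 35%.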

Compound 3, a percentage reported as inhibition, at one concentration (the size of the read-out at that concentration, not a potency): 13.1%
Estimate against measurement, compound 3: 8.9 percentage points above; low and high end bracket the measured number.
By their numbers in this assay, from the lowest: compounds 3 and 1 (each within the scatter of the next); then compound 2.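

In this assay, replacing 3,4-dimethylphenyl with 3-(tert-butyl)phenyl gives a number 16.4 percentage points lower from compound 2 to compound 3 (beyond the scatter), so on this nitrogen a tert-butyl group in this second arrangement also falls short of the dimethylphenyl group. Exchanging one tert-butylphenyl group for the other gives a number 4.4 percentage points lower from compound 1 to compound 3 (within the scatter), so this assay does not separate the two, and only compound 2 stands apart. No measurement offered here explains these differences. On these data alone, whether a single methyl group, a methoxy group or an amine on this phenyl ring would match or pass compound 2 remains open.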